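A few compounds are considered here, and "the series" means these few. Any claim that something is new, unique, unknown or untested is made for them only; others in the source may bear on it.

The series shares one core, carried in compound 3 `Cc1ncnc2c1c(-c1ccsc1)cn2[C@@H]1O[C@H](CO)[C@@H](O)[C@H]1O`, compound 1 `CNc1ncnc2c1c(-c1ccsc1)cn2[C@@H]1O[C@H](CO)[C@@H](O)[C@H]1O` and compound 2 `C#Cc1cn([C@@H]2O[C@H](CO)[C@@H](O)[C@H]2O)c2ncnc(N(C)C)c12`. In a functional assay on A549 cells (Homo sapiens), read by MTT assay, with a stated time of 72 h (a lower number here means a stronger inhibitor, a higher number a weaker inhibitor), compound 3 returns only a limit of the assay, > 20000 nM. Compound 1 likewise returns only a limit in this assay, > 20000 nM. Compound 2 is read with a number in this assay, 390 nM. The change from compound 1 to compound 3, methyl in place of methylamino on an aromatic carbon, is a step that the two limits leave unreadable from compound 1 to compound 3; its size cannot be told since (the limit of > 20000 nM in this assay, at which 2 of the 3 values shown sit).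

Compound 4 `CN(C)c1ncnc2c1c(-c1ccsc1)cn2[C@@H]1O[C@H](CO)[C@@H](O)[C@H]1O` is not yet measured. It differs from compound 3 by dimethylamino in place of methyl on an aromatic carbon. Going by the values given here, no measured step bears on this change directly. Among the compounds with values here, compound 2 carries the same dimethylamino group but differs from compound 4 in a second place as well, so its value shows only that a compound with this group can be read with a number. Compound 3 offers only a limit from which to anchor the expected step of a number no higher from compound 3 to compound 4 (the limit leaves the size open). Compound 4 is therefore expected to give about 20000 nM in this assay, between 3000 nM and 100000 nM, with a real chance that again only a limit is reported.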

Compound 4, half-maximal inhibitory concentration: > 20000 nM
Compound 4: no number, only a limit; the forecaster's own chance of this, stated with the estimate: 55%; the middle value lies on the limit itself.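

With thiophen-3-yl on the shared core, dimethylamino now joins methyl and methylamino at the limit of this assay, so none of these three groups on this aromatic carbon gives a number with thiophen-3-yl present. Going by these compounds alone, the one readable step holds dimethylamino fixed and changes the other place, with thiophen-3-yl in place of ethynyl giving an at least 51-fold higher number from compound 2 to compound 4 (1.70 log units; beyond the scatter), so dimethylamino alone does not secure a readable value. The steps among compound 1, compound 3 and compound 4 cannot be read because all three values are limits: the limit of > 20000 nM in this assay, at which 3 of the 4 values shown sit.

Open, from the compounds shown here alone, is whether methyl or methylamino on the aromatic carbon would also give a number alongside ethynyl. Also open, going by these compounds, is how a nitrile or a longer alkyne chain in place of thiophen-3-yl would read with dimethylamino retained.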